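The source may report more compounds than this note shows. Statements on the series, on what has been measured and on what is new or still open speak of the compounds shown alone.

The measured compounds are:
compound 1, `CCN1CCN(CC(=O)Nc2ccc(-c3nc(-c4ccccc4)c(-c4ccccc4)n3C)cc2)CC1`, which in a functional assay on HT-29 cells (Homo sapiens) for cytotoxicity, read by MTT assay, with a stated time of 24 h, tested at 1.6 ug/mL (a lower number here means a weaker effect, a higher number a stronger effect of the compound at the concentration tested), gives 13.9%;
compound 2, `Cn1c(-c2ccc(NC(=O)CN3CCN(c4ccccc4)CC3)cc2)nc(-c2ccccc2)c1-c1ccccc1`, which in this assay gives 26%.

Among the compounds with values here, compound 2 holds the higher of the two numbers, and the single measured step, a number 12.1 percentage points higher from compound 1 to compound 2 (beyond the scatter), is the gap that sets it apart.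

Compound 3, `Cc1ccc(CN2CCN(CC(=O)Nc3ccc(-c4nc(-c5ccccc5)c(-c5ccccc5)n4C)cc3)CC2)cc1`, has not yet been measured in this assay. It differs from compound 2 in one place: 4-methylbenzyl in place of phenyl on an amine nitrogen in a ring.

Within the data shown here, the only measured step that touches this position is a number 12.1 percentage points higher from compound 1 to compound 2 (beyond the scatter), where the group on the same ring nitrogen was also exchanged. Among the measured compounds shown here, that step was modest, and no measured compound carries a 4-methylbenzyl group at this place, so there is no direct precedent for the new group. A shift of similar or smaller size than that step is therefore expected, in either direction, or none beyond the scatter.

For compound 3 the expected value in this assay is 24%, within a range from 8% to 42%. The step this estimate implies, a number 2 percentage points lower from compound 2 to compound 3 (within the scatter), is expected to stay within the scatter.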

Compound 3, a percentage reported as activity, at one concentration (the size of the read-out at that concentration, not a potency): 26.4%
For compound 3 the middle estimate is 2.4 percentage points below the measured one, and the stated range covers the measured number.
By their numbers in this assay, from the lowest: compound 1; then compounds 2 and 3 (each within the scatter of the next).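

In this assay, the ring nitrogen accepts a clear change of group without a visible change in the read-out: replacing phenyl with 4-methylbenzyl gives a number 0.4 percentage points higher from compound 2 to compound 3 (within the scatter). The entering group is larger and places its aromatic ring one carbon further from the nitrogen, yet this difference does not separate the two compounds. The step from the ethyl group to 4-methylbenzyl gives a number 12.5 percentage points higher from compound 1 to compound 3 (beyond the scatter), so among these three compounds, both groups containing an aromatic ring stand apart from ethyl, with none going against this small pattern; nothing shown here offers an explanation for that gap.

The compounds shown leave open whether the aromatic ring itself matters or whether any group larger than ethyl would do, and a longer chain such as n-hexyl, which has no ring, would help separate the two. Also open, going by these compounds, is how a plain benzyl group, or a pyridine ring carrying a nitrogen atom, would compare on this same ring nitrogen, since the read-out here comes from one concentration and does not give a potency.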